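The source may hold more compounds than are shown below. What is called first, only, known or untested is meant among the compounds shown, and "the series" means these compounds.

Measured so far:
compound 1 `Cc1ccc(-n2nc(-c3ccccc3)nc2CNc2ccc(C(=O)NO)cc2)cc1` gives 60.7% in an assay on Sf9 cells for inhibition of protein deacetylase HDAC6 (Homo sapiens), read by fluorescence, with a stated time of 40 min, tested at 100 nM; a higher number here means more inhibition at the concentration tested (going by the name of the read-out), a lower number less inhibition;
compound 2 `O=C(NO)c1ccc(NCc2nc(-c3ccccc3)nn2-c2cccc(Cl)c2)cc1` gives 62.3% in this assay.

Of these two numbers, compound 2 holds the higher, but the step of a number 1.6 percentage points higher from compound 1 to compound 2 (within the scatter) is within the scatter, so the two are indistinguishable. Compound 3 `O=C(NO)c1ccc(NCc2nc(-c3ccccc3)nn2-c2ccccc2)cc1` differs from compound 2 by hydrogen in place of chloro on an aromatic carbon. Within the data shown here, the only measured step, a number 1.6 percentage points higher from compound 1 to compound 2 (within the scatter), also changed the group on the aromatic nitrogen and did not move the read-out beyond the scatter, so no step beyond the scatter is expected in this assay here either. Compound 3 is therefore estimated at 58%, between 42% and 74%, a step of a number 4.3 percentage points lower from compound 2 to compound 3 (within the scatter) expected.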

Compound 3, a percentage reported as inhibition, at one concentration (the size of the read-out at that concentration, not a potency): 72.6%
Compound 3: the middle estimate sits 14.6 percentage points below what was measured; measured number inside the range.
By their numbers in this assay, from the lowest: compounds 1 and 2 (each within the scatter of the next); then compound 3.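

In this assay, taking the chloro off the 3-chlorophenyl group gives a number 10.3 percentage points higher from compound 2 to compound 3 (beyond the scatter) and taking the methyl off the 4-methylphenyl group gives a number 11.9 percentage points higher from compound 1 to compound 3 (beyond the scatter). So a change on this ring can move the read-out beyond the scatter, and the plain phenyl stands above both substituted rings, while chloro and methyl remain indistinguishable from each other. No measurement at hand explains this gain.

Going by these compounds, whether a fluoro, a methoxy or an amine on this ring would also fall short of compound 3 stays open. So does whether a chloro elsewhere on the ring would behave like the one removed.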